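This account rests on a few compounds, and the source may have more. Where it says the series, first, only, none or still open, it means among the compounds named here.

Measured compounds in this series:

compound 1 `O=C(/C=C/c1ccc(OCc2cn(Cc3cccc(Br)c3)nn2)cc1)c1ccc(Br)cc1` — 36%
compound 2 `O=C(/C=C/c1ccc(OCc2cn(Cc3ccc(Br)cc3)nn2)cc1)c1ccc(Br)cc1` — 23%

Within the data shown here, in a functional assay on MCF7 cells (Homo sapiens) for inhibition, read by MTT assay, with a stated time of 48 h, tested at 10 uM (a higher number here means more inhibition of growth at the concentration tested, a lower number less inhibition of growth), compound 2 stands lowest of the two numbers measured so far; the nearest is compound 1, and the step of a number 13 percentage points lower from compound 1 to compound 2 (beyond the scatter) is the only measured step in the set.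

Compound 3 `O=C(/C=C/c1ccc(OCc2cn(Cc3cccc(F)c3)nn2)cc1)c1ccc(Br)cc1` has not yet been measured. It differs from compound 2 as 3-fluorophenyl in place of 4-bromophenyl on a saturated chain carbon bound to an aromatic nitrogen. Among the measured compounds shown here, the one measured step at this place is a number 13 percentage points lower from compound 1 to compound 2 (beyond the scatter), which exchanged 3-bromophenyl for 4-bromophenyl. For the measured compounds named here, compound 3 returns to a ring substituted in the 3-position, but with fluorine in place of bromine, and no measured step covers that halogen exchange. A modest rise from compound 2 back toward the number of compound 1 is therefore expected, a number 9 percentage points higher from compound 2 to compound 3 (within the scatter), with wide uncertainty. For compound 3 the estimate in this assay is 32%, within a range of 18% to 46%.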

Compound 3, percent growth inhibition at one concentration: 42%
For compound 3 the middle estimate is 10 percentage points below the measured one; the range from low to high includes it.
By their numbers in this assay, from the lowest: compound 2; then compounds 1 and 3 (each within the scatter of the next).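

In this assay, 3-fluorophenyl in place of 4-bromophenyl on a saturated chain carbon bound to an aromatic nitrogen gives a number 19 percentage points higher from compound 2 to compound 3 (beyond the scatter), so this place now shows a second step beyond the scatter, both steps involving compound 2. Fluoro in place of bromo on an aromatic carbon gives a number 6 percentage points higher from compound 1 to compound 3 (within the scatter), so the 3-bromophenyl and 3-fluorophenyl groups are not told apart here, and among these three compounds only the 4-bromophenyl group of compound 2 stands apart. No measured evidence bears on the reason for these differences.

The compounds shown leave open whether a 4-fluorophenyl group would read with compound 2 or with compound 3, which would test whether the halogen matters at that ring position. They also leave open how an unsubstituted phenyl, or a phenyl carrying an amine or a carboxylic acid, would read at this place.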